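A Ring Reattached: From Compound 2 to Compound 3

A few compounds are considered here, and "the series" means these few. Any claim that something is new, unique, unknown or untested is made for them only; others in the source may bear on it.

Of the compounds shown here, two that share one core have been tested so far in an ADME assay on microsomes from liver (Mus musculus) for metabolic stability, read by LC-MS, using NADPH, with stated times of 15 min and 60 min, tested at 4.6 uM; on this read-out higher numbers stand for a longer-lived compound and lower numbers for a shorter-lived compound. Compound 1 (`CN1CCC(c2ccc3c(c2)oc(=O)n3C(=O)NCCCCc2ccccc2)CC1=O`) gives 0.583 h. Compound 2 (`CC(C)CNC(=O)n1c(=O)oc2cc(C3CCCCN3C)ccc21`) gives 0.25 h, the lower of the two numbers, and the gap between them is larger than repeated measurements would normally produce. These two compounds differ in more than one place, so their gap says little about any single change.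

Compound 3 (`CC(C)CNC(=O)n1c(=O)oc2cc(C3CCN(C)CC3)ccc21`) has not yet been measured in this assay. It keeps every atom of compound 2 but joins them differently, with 1-methylpiperidin-4-yl in place of 1-methylpiperidin-2-yl on an aromatic carbon. Going by the values given here, no measured pair isolates such a change, so the expectation starts from compound 2 at 0.25 h. The expected step is a 1.4-fold higher number from compound 2 to compound 3 (0.15 log units; within the scatter), a slight rise that stays within the usual scatter. For compound 3 the estimated half-life is 0.35 h, with an expected range of 0.15 h to 0.85 h.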

Compound 3, half-life: > 1 h
Compound 3 was reported as a limit (the forecaster's own chance of this, stated with the estimate: 5%); middle value at least 2.8-fold (0.45 log units) away from the limit.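

Replacing 1-methylpiperidin-2-yl with 1-methylpiperidin-4-yl on an aromatic carbon gives an at least 4.0-fold higher number from compound 2 to compound 3 (0.60 log units; beyond the scatter) in this assay, and this is the only step shown that isolates a single change. At this position, then, the point at which the piperidine ring is joined to the core matters for the half-life, even though the two groups hold the same atoms and match in every count computed for them. The value of compound 3, > 1 h, is a limit of the assay and not a number: the limit of > 1 h in this assay, at which 1 of the 3 values shown sits.

As far as these compounds go, how far the half-life of compound 3 lies past that limit stays open, so the full size of the step is unknown. Also open, from the compounds shown here alone, is how the remaining attachment point would read, as 1-methylpiperidin-3-yl, and whether the methyl group on the ring nitrogen plays a part, which a piperidin-4-yl group with a hydrogen on that nitrogen could help to show.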